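Swapping the Cap on a Shared Core

A few compounds are considered here, and "the series" means these few. Any claim that something is new, unique, unknown or untested is made for them only; others in the source may bear on it.

Two compounds share a common core and differ only in the group attached to one carbonyl carbon. Compound 1 `CN(C)c1ccc(C(=O)NC(CCCCCC(=O)NO)C(=O)NC2CCCc3ccccc32)cc1` and compound 2 `O=C(CCCCC[C@H](NC(=O)c1cc2ccccc2[nH]1)C(=O)NCc1ccccc1)NO` have both been tested in a functional assay on NFF cells (Homo sapiens) for antiproliferative activity; on this read-out higher numbers stand for weaker inhibition and lower numbers for stronger inhibition. In this assay compound 1 gives 1810 nM. In this assay compound 2 gives 1260 nM. These two numbers lie within the usual scatter of each other, so they cannot be told apart with confidence; compound 2 simply carries the lower number of the two shown.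

Compound 3 `O=C(/C=C/c1ccccc1)N[C@@H](CCCCCC(=O)NO)C(=O)NCc1ccccc1` has not yet been measured. It differs from compound 2 at a single place: 2-phenylethenyl in place of 1H-indol-2-yl on a carbonyl carbon. The change removes a hydrogen-bond donor and replaces a fused two-ring group with a single ring carrying a double bond outside aromatic rings, while the rest of the molecule stays the same.

For the measured compounds named here, with no measured step available to calibrate this kind of exchange, the expectation is that the step from compound 2 to compound 3 in this assay, a 1.2-fold higher number from compound 2 to compound 3 (0.08 log units; within the scatter), stays within the scatter. Compound 3 is therefore estimated at 1500 nM, with a range from 500 nM to 4500 nM.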

Compound 3, half-maximal inhibitory concentration: 4010 nM
Estimate against measurement, compound 3: 2.7-fold (0.43 log units) below, and the stated range covers the measured number.
By their numbers in this assay, from the lowest: compounds 2 and 1 (each within the scatter of the next); then compound 3.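

For the compounds shown here, this is the first measured step at this position, the carbonyl carbon whose other neighbour is an amide-type nitrogen, and it shows that the group placed there can matter: in this assay, 2-phenylethenyl in place of 1H-indol-2-yl gives a 3.2-fold higher number from compound 2 to compound 3 (0.50 log units; beyond the scatter), a step beyond the usual scatter. Several things change together in this exchange, since the hydrogen-bond donor and the five-membered aromatic ring leave while a double bond outside aromatic rings enters, so this one step cannot show which of these changes accounts for the difference. No supporting measurement is available to explain the higher number of compound 3.

The compounds shown leave open whether the ring nitrogen with its hydrogen is what counts, and a 1-benzofuran-2-yl group, which keeps the two fused rings but has oxygen in place of that nitrogen, would test this directly. They also leave open the role of the double bond, which a 2-phenylethyl group would address, and whether the same exchange gives a similar step on the core of compound 1.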